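Ethyl to isopropyl on the ester of compound 3

A few compounds are considered here, and "the series" means these few. Any claim that something is new, unique, unknown or untested is made for them only; others in the source may bear on it.

In a functional assay on the whole organism for inhibition, with Rattus norvegicus as the target, read by paw edema, with stated times of 1 h and 3 h (on this read-out lower numbers stand for an effect already at smaller amounts and higher numbers for an effect only at larger amounts of compound), compound 1 `C/C(=N\OCCC(=O)O)c1ccc(Cl)cc1` gives 80 mg/kg and compound 2 `C/C(=N\OCCCC(=O)O)c1ccc(Cl)cc1` gives 58 mg/kg while compound 3 `CCOC(=O)CO/N=C(\C)c1ccc(Cl)cc1`, which carries the ethoxycarbonyl group, gives 32 mg/kg on the same scale. The series shows a 2.5-fold lower number from compound 1 to compound 3 (0.40 log units; beyond the scatter) and a 1.8-fold lower number from compound 2 to compound 3 (0.26 log units; within the scatter), so compound 3 is separated from compound 1 only and not from compound 2.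

The next structure is compound 4 `C/C(=N\OCC(=O)OC(C)C)c1ccc(Cl)cc1`. Its difference is methyl in place of hydrogen on a saturated chain carbon bound to an oxygen next to a carbonyl group and a saturated chain carbon, which reads as ethoxycarbonyl to isopropoxycarbonyl.

Going by the values given here, no measured pair varies this ester group, so no step in hand speaks to the change directly. The measured steps bear on it only as a guide to size. Alongside the two above, the series shows a 1.4-fold lower number from compound 1 to compound 2 (0.14 log units; within the scatter) and nothing larger than a modest step, even where the carboxy-ended chains give way to the ethoxycarbonyl group. A single added methyl is therefore expected to give no step beyond the scatter in this assay and no direction is favoured. The expected result is a 1.1-fold lower number from compound 3 to compound 4 (0.03 log units; within the scatter) as an estimate only. Compound 4 is estimated at 30 mg/kg with an expected range from 15 mg/kg to 60 mg/kg in this read-out.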

Compound 4, dose for half-maximal effect: 50 mg/kg
Compound 4: middle estimate off by 1.7-fold (0.22 log units), on the low side; low and high end bracket the measured number.
By their numbers in this assay, from the lowest: compounds 3, 4, 2 and 1 (each within the scatter of the next, the first and the last beyond it).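

In this assay, the only variation of the ester's alkyl group, ethoxycarbonyl to isopropoxycarbonyl, gives a step that does not separate the two esters (a 1.6-fold higher number from compound 3 to compound 4 (0.19 log units; within the scatter)), so one added methyl on the saturated chain carbon bound to an oxygen has no effect that can be told from the scatter. Compound 4 is also not separated from either carboxy-ended chain (a 1.2-fold lower number from compound 2 to compound 4 (0.06 log units; within the scatter); a 1.6-fold lower number from compound 1 to compound 4 (0.20 log units; within the scatter)), so the one separation beyond the scatter seen earlier, between compound 1 and compound 3, holds for the ethoxycarbonyl group and does not carry over to the isopropoxycarbonyl group. Nothing measured on these compounds offers an explanation for these steps.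

On these data alone, whether a methyl ester, a tert-butyl ester or a benzyl ester would stand apart from compound 3 on this scale remains open, and a larger group at this position might show a limit that a single methyl does not reach. Also open, as far as these compounds go, is how the free carboxylic acid or a primary amide on the same short chain would compare with the ethoxycarbonyl group of compound 3.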